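This account rests on a few compounds, and the source may have more. Where it says the series, first, only, none or still open, it means among the compounds named here.

Three compounds have been measured in a functional assay on HeLa cells (Homo sapiens) for inhibition, read by sulforhodamine B assay, with a stated time of 48 h; a lower number here means a stronger inhibitor of growth, a higher number a weaker inhibitor of growth:

compound 1 `CC(=O)OC/C(=C\c1ccc(Cl)cc1Cl)C(=O)c1ccc(Cl)cc1` gives 4600 nM
compound 2 `O=C(OC/C(=C/c1ccccc1[N+](=O)[O-])C(=O)c1ccccc1)c1ccccc1` gives 30000 nM
compound 3 `C=C(C/C(=C\c1ccccc1)C(=O)c1ccccc1)C(=O)c1ccccc1` gives 19000 nM

Among these three numbers compound 3 holds the second highest. Its nearest neighbour is compound 2, and the two values lie within the usual scatter of each other, so nothing can be said about which of the two is the stronger growth inhibitor. Compound 1 is further away, with the lower number, and that gap lies beyond the scatter, so compound 1 is the stronger inhibitor of the three on the numbers shown.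

Compound 4 `C=C(C/C(=C\c1ccc(OC)cc1)C(=O)c1ccccc1)C(=O)c1ccccc1` has not yet been measured. It differs from compound 3 in one place: methoxy in place of hydrogen on an aromatic carbon. Going by the values given here, no pair of already measured compounds shows this same change, so there is no measured step to lean on. In this assay a change of this kind is expected to produce at most a small step, and its direction is uncertain. The working estimate is that compound 4 will give 15000 nM, within a range from 5000 nM to 45000 nM, so that the expected step is a 1.3-fold lower number from compound 3 to compound 4 (0.10 log units; within the scatter), not clearly beyond the scatter.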

Compound 4, concentration for 50% growth inhibition: 320 nM
The estimate for compound 4 lay 47-fold (1.67 log units) above the measured number; the measured number lies below the stated range.
By their numbers in this assay, from the lowest: compound 4; then compound 1; then compounds 3 and 2 (each within the scatter of the next).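

In this assay, going by these compounds alone, putting methoxy in place of hydrogen on an aromatic carbon gives a 59-fold lower number from compound 3 to compound 4 (1.77 log units; beyond the scatter), the first reading of a single change in these compounds, since no two of the earlier ones differ in only one place. The change adds only 2 heavy atoms, yet this phenyl to 4-methoxyphenyl swap shows that growth inhibition in this pair depends strongly on what sits at this position, para to a large group. No measurement shown here bears on why the step is so large.

From the compounds shown here alone, it remains open whether methoxy is special at this position, or whether a hydroxyl group, a methyl group, an amine, a carboxylic acid or a longer chain such as ethoxy on the same carbon would bring a similar step. Going by these compounds, it also remains open whether the same change would have a comparable effect on the different cores of compound 1 and compound 2, as a single pair cannot show whether the step carries over to other compounds.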